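A few compounds are considered here, and "the series" means these few. Any claim that something is new, unique, unknown or untested is made for them only; others in the source may bear on it.

Working notes on the series. Compound 2 `COc1ccc(Nc2nc(Oc3cccc(NC(=O)/C=C/C(C)C)c3)c3sccc3n2)cc1` and compound 1 `COc1ccc(Nc2nc(Oc3cccc(NC(=O)C=C(C)C)c3)c3sccc3n2)cc1` share the same core and differ only at the amide; in a functional assay on HeLa cells (Homo sapiens) for inhibition, read by MTT assay, with a stated time of 72 h (a lower number here means a stronger inhibitor, a higher number a weaker inhibitor), compound 2 gives 45100 nM, while compound 1 gives 28800 nM. Within the data shown here, the only measured step, a 1.6-fold higher number from compound 1 to compound 2 (0.19 log units; within the scatter), concerns the 3-methylbut-1-en-1-yl group on the carbonyl carbon, and the two values lie within the scatter of each other, so compound 2 cannot be set apart from compound 1 on these numbers.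

Compound 3 `CC(C)/C=C/C(=O)Nc1cccc(Oc2nc(Nc3cccc(C#N)c3)nc3ccsc23)c1` keeps the amide of compound 2 and changes the other end of the molecule: 3-cyanophenyl in place of 4-methoxyphenyl on a nitrogen on an aromatic ring. Among the measured compounds shown here, no measured step touches that nitrogen, so the change from compound 2 to compound 3 has no precedent in this set, and the single amide step gives no guidance on its size or direction. The expectation for this assay is therefore drawn from the value of compound 2 alone, with a wide range on either side. On that basis compound 3 is estimated at 45000 nM in this assay, between 10000 nM and 200000 nM, which amounts to an expected step of a 1.0-fold lower number from compound 2 to compound 3 (0.00 log units; within the scatter).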

Compound 3, half-maximal inhibitory concentration: 36500 nM
Beside the measured number, compound 3's estimate is 1.2-fold (0.09 log units) above it; the range from low to high includes it.
By their numbers in this assay, from the lowest: compounds 1, 3 and 2 (each within the scatter of the next).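

In this assay, among these compounds, the exchange of 4-methoxyphenyl for 3-cyanophenyl on a nitrogen on an aromatic ring gives a 1.2-fold lower number from compound 2 to compound 3 (0.09 log units; within the scatter), the first reading at this position, which until now had no measured step. The two aryl groups therefore cannot be told apart on this read-out, and with the amide step, a 1.6-fold higher number from compound 1 to compound 2 (0.19 log units; within the scatter), also inside the scatter, neither of the two places varied in these compounds has yet produced a separable difference. No data on the cause of this result are available.

What the compounds leave open is whether this nitrogen substituent can shift the number at all, since a single pair, with one nitrile and one methoxy group on the phenyl ring, says nothing about the effect of either group alone or of its place on that ring. An unsubstituted phenyl, a phenyl carrying an amine or a carboxylic acid, or a longer alkyl chain in place of the aryl group would show whether the flat reading of compound 2 and compound 3 holds beyond this pair.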